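The source may report more compounds than this note shows. Statements on the series, on what has been measured and on what is new or still open speak of the compounds shown alone.

Of the compounds shown here, three sharing one core have been tested in a functional assay on HepG2 cells (Homo sapiens) for cytotoxicity, read by MTT assay, with a stated time of 24 h; a lower number here means a stronger inhibitor, a higher number a weaker inhibitor. Compound 1 `Cc1ccc(S(=O)(=O)N2C/C(=C\c3ccccc3F)C(=O)/C(=C/c3ccccc3F)C2)cc1` gives 14200 nM. Compound 2 `O=C1/C(=C/c2ccccc2F)CN(S(=O)(=O)c2ccc(O[N+](=O)[O-])cc2)C/C1=C\c1ccccc1F` gives 16500 nM. Compound 3 `O=C1/C(=C/c2ccccc2F)CN(S(=O)(=O)c2ccc(F)cc2)C/C1=C\c1ccccc1F` gives 8000 nM. Compound 3 has the lowest number of the three, but its gap to compound 1 is small: a 1.8-fold lower number from compound 1 to compound 3 (0.25 log units; within the scatter). Its gap to compound 2 is only slightly larger: a 2.1-fold lower number from compound 2 to compound 3 (0.31 log units; beyond the scatter). Compound 4 `N#Cc1ccc(S(=O)(=O)N2C/C(=C\c3ccccc3F)C(=O)/C(=C/c3ccccc3F)C2)cc1` differs from compound 3 by one exchange: cyano in place of fluoro on an aromatic carbon. The two steps already seen, a 1.8-fold lower number from compound 1 to compound 3 (0.25 log units; within the scatter) and a 2.1-fold lower number from compound 2 to compound 3 (0.31 log units; beyond the scatter), are also exchanges of the group on that same aromatic carbon, and both were modest or within the scatter, so the expected step in this assay is small, with the number for compound 4 expected to sit a little higher than that of compound 3, as a 1.3-fold higher number from compound 3 to compound 4 (0.10 log units; within the scatter). Compound 4 is therefore expected to give 10000 nM, with a likely range from 5000 nM to 25000 nM.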

Compound 4, half-maximal inhibitory concentration: 16500 nM
Compound 4: the middle estimate sits 1.7-fold (0.22 log units) below what was measured, within the range that was stated.
By their numbers in this assay, from the lowest: compounds 3, 1, 2 and 4 (each within the scatter of the next, the first and the last beyond it).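

In this assay, cyano gives a second exchange at this aromatic carbon that ends beyond the scatter when set against fluoro, though the step stays modest, with a 2.1-fold higher number from compound 3 to compound 4 (0.31 log units; beyond the scatter). Cyano cannot be told apart from the other two groups tested here, with no change at the digits printed from compound 2 to compound 4 (within the scatter) and a 1.2-fold higher number from compound 1 to compound 4 (0.07 log units; within the scatter), so methyl, nitrooxy and cyano all read alike, while fluoro stands apart from nitrooxy and cyano but not from methyl. Nothing available bears on why fluoro and cyano differ at this position.

On these data alone, it remains open whether an amine or a carboxylic acid on this carbon would move the number further than this narrow spread. As far as these compounds go, it is also open whether these exchanges would give the same small steps if the rest of the shared core were changed.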